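Urea-linked anilinopyrimidines tested for cell growth inhibition

The source may hold more compounds than are shown below. What is called first, only, known or untested is meant among the compounds shown, and "the series" means these compounds.

Compound 1 `COc1ccc(F)cc1Nc1cc(NC(=O)Nc2c(Cl)cccc2Cl)ncn1`: 38.1%
Compound 2 `COc1cc(NC(=O)Nc2cc(Nc3cc(F)ccc3OC)ncn2)cc(OC)c1`: 38%
Compound 3 `COc1ccc(C(F)(F)F)cc1Nc1cc(NC(=O)Nc2c(Cl)cccc2Cl)ncn1`: 33%

In a functional assay on NCI-H520 cells (Homo sapiens) for inhibition, read by MTT assay, with a stated time of 48 h, tested at 10 uM (a higher number here means more inhibition at the concentration tested (going by the name of the read-out), a lower number less inhibition), compound 1 gives 38.1%, the highest of the three numbers, but its nearest neighbour compound 2 at 38% and the furthest, compound 3 at 33%, both sit within the scatter of it, so no order among the three can be claimed. The step of a number 0.1 percentage points lower from compound 1 to compound 2 (within the scatter) came with a 3,5-dimethoxyphenyl in place of a 2,6-dichlorophenyl on an amide-type nitrogen, and the step of a number 5.1 percentage points lower from compound 1 to compound 3 (within the scatter) with a trifluoromethyl in place of a fluoro on an aromatic carbon.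

Compound 4 `CCc1ccc(Nc2cc(NC(=O)Nc3c(Cl)cccc3Cl)ncn2)cc1` has not been measured. It differs from compound 1 by 4-ethylphenyl in place of 5-fluoro-2-methoxyphenyl on a nitrogen on an aromatic ring. Among the measured compounds shown here, of the measured steps only the one from compound 1 to compound 3 touches the same aryl group, and that step was within the scatter. A change of the whole aryl at this nitrogen has no measured parallel, so the data give little ground for a large move in either direction. Compound 4 is therefore expected to show a step of a number 3.1 percentage points lower from compound 1 to compound 4 (within the scatter) in this assay, and its estimated value is 35%, within a range of 18% to 52%.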

Compound 4, a percentage reported as inhibition, at one concentration (the size of the read-out at that concentration, not a potency): 31.5%
Beside the measured number, compound 4's estimate is 3.5 percentage points above it, within the range that was stated.
By their numbers in this assay, from the lowest: compounds 4, 3, 2 and 1 (each within the scatter of the next).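

Swapping the whole aryl group on this nitrogen, with 4-ethylphenyl in place of 5-fluoro-2-methoxyphenyl, gives a number 6.6 percentage points lower from compound 1 to compound 4 (within the scatter) in this assay. Among the compounds shown here, this shows more than the earlier compounds could: each of them kept a methoxy on this aryl group and changed only the other aryl group or the substituent that replaced the fluoro, whereas compound 4 carries neither the methoxy nor the fluoro, and its oxygen-free, all-carbon group still leaves the number within the scatter of compound 1. Nothing given here explains why the exchange of this group leaves the reading in that range, and no independent measurement bears on it.

What the compounds shown leave open is whether any group on this nitrogen can move the number beyond the scatter, for instance a longer chain such as butyl in place of the ethyl, or a carboxylic acid or a primary amine on this aryl group. They also leave open how compounds 1 and 4 would compare as potencies, as the read-out gives the size of the inhibition at a single concentration only.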